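The source may hold more compounds than are shown below. What is called first, only, known or untested is meant among the compounds shown, and "the series" means these compounds.

Series notes in an assay on liver for binding affinity to Alpha-1D adrenergic receptor (Homo sapiens), using microsomes; on this read-out lower numbers stand for stronger inhibition and higher numbers for weaker inhibition. Compound 1 `COC(=O)C1=C(C)NC(=O)N(C(=O)NCCCN2CCN(c3ccccc3OC)CC2)C1c1ccc(F)c(F)c1` gives 31 nM; compound 2 `CCC1=C(C(N)=O)C(c2ccc(F)cc2F)N(C(=O)NCCCN2CCN(c3ccccc3C(N)=O)CC2)C(=O)N1` gives 1100 nM; compound 3 `COC(=O)C1=C(C)NC(=O)N(C(=O)NCCCN2CCN(c3ccc(Cl)cc3)CC2)C1c1ccc(F)c(F)c1` gives 52 nM. Compound 3 stands second highest of the three numbers in this assay, nearest to compound 1 and well apart from compound 2. For the measured compounds named here, the only single-point change measured so far on the aryl group of the ring amine, a 1.7-fold higher number from compound 1 to compound 3 (0.22 log units; within the scatter), lies within the scatter. Compound 4 `COC(=O)C1=C(C)NC(=O)N(C(=O)NCCCN2CCN(c3cccc(Cl)c3)CC2)C1c1ccc(F)c(F)c1` differs from compound 3 by 3-chlorophenyl in place of 4-chlorophenyl on an amine nitrogen in a ring. Going by the values given here, no measured step moves the chlorine about that ring, and the one aryl replacement in hand was small, so only a modest step in this assay is expected for compound 4, with no direction favoured. Compound 4 is estimated at 60 nM, range 20 nM to 180 nM, a step of a 1.2-fold higher number from compound 3 to compound 4 (0.06 log units; within the scatter) expected to fall within the scatter.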

Compound 4, inhibition constant: 37 nM
Estimate against measurement, compound 4: 1.6-fold (0.21 log units) above; the range from low to high includes it.
By their numbers in this assay, from the lowest: compounds 1, 4 and 3 (each within the scatter of the next); then compound 2.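

In this assay, the chlorine change gives a 1.4-fold lower number from compound 3 to compound 4 (0.15 log units; within the scatter), so this position on the amine nitrogen in a ring does not separate 3-chlorophenyl from 4-chlorophenyl. The replacement of 2-methoxyphenyl gives a 1.2-fold higher number from compound 1 to compound 4 (0.08 log units; within the scatter), so a second chlorophenyl group also stays within the scatter of that aryl group. Nothing at hand explains either step.

Still open, from the compounds shown here alone, is whether 2-chlorophenyl at this position would stay within the same scatter. Also open, going by these compounds, is whether a pyridyl ring or a cyclohexyl group on that nitrogen would hold the value of compound 4.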